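Iodo for isopropyl on the shared core: antiproliferation notes

The source may hold more compounds than are shown below. What is called first, only, known or untested is meant among the compounds shown, and "the series" means these compounds.

Measured so far:
Compound 1 `CCCNC(=O)Nc1ccc(S(=O)(=O)Oc2ccccc2C(C)C)cc1` gives 5100 nM in a functional assay on M21 cells (Homo sapiens) for antiproliferative activity, read by sulforhodamine B assay, with a stated time of 48 h; a lower number here means a stronger inhibitor, a higher number a weaker inhibitor.
Compound 2 `CCCNC(=O)Nc1ccc(S(=O)(=O)Oc2ccccc2I)cc1` gives 5400 nM in this assay.
Compound 3 `CC(C)c1ccccc1OS(=O)(=O)c1ccc(NC(=O)NCCCCl)cc1` gives 9300 nM in this assay.

All three numbers lie close together. Compound 2 differs from compound 1 by iodo in place of isopropyl on an aromatic carbon, and the step is a 1.1-fold higher number from compound 1 to compound 2 (0.02 log units; within the scatter). Compound 3 differs from compound 1 by chloro in place of hydrogen on a saturated chain carbon, three bonds along the chain from an amide-type nitrogen, and the step is a 1.8-fold higher number from compound 1 to compound 3 (0.26 log units; within the scatter). Neither step leaves the scatter, so no order among the three can be read from these values.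

Compound 4 `O=C(NCCCCl)Nc1ccc(S(=O)(=O)Oc2ccccc2I)cc1` has not yet been measured in this assay. It differs from compound 3 by iodo in place of isopropyl on an aromatic carbon, the same change that was made from compound 1 to compound 2, with the place around it described in the same words. The two cores on which this change is made differ in the way given for compound 1 and compound 3 above, the chloropropyl chain in place of the propyl chain.

The step from compound 3 to compound 4 is expected to be a 1.1-fold higher number from compound 3 to compound 4 (0.03 log units; within the scatter), resting on the earlier step of a 1.1-fold higher number from compound 1 to compound 2 (0.02 log units; within the scatter), which stayed within the scatter. Compound 4 is therefore estimated at 10000 nM, with a likely range from 5000 nM to 20000 nM.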

Compound 4, half-maximal inhibitory concentration: 4600 nM
Compound 4: middle estimate off by 2.2-fold (0.34 log units), on the high side; measured number outside the range, below it.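

In this assay, iodo in place of isopropyl on the chloropropyl core gives a 2.0-fold lower number from compound 3 to compound 4 (0.31 log units; beyond the scatter), and chloro in place of hydrogen on the chain of the iodo core gives a 1.2-fold lower number from compound 2 to compound 4 (0.07 log units; within the scatter). Set beside its earlier counterpart, the iodo change shows no measurable difference between the two cores, although only the new step lies beyond the scatter: the same change on two cores in this assay, a 1.1-fold higher number (0.02 log units; within the scatter) from compound 1 to compound 2 and a 2.0-fold lower number (0.31 log units; beyond the scatter) from compound 3 to compound 4, 2.1-fold (0.33 log units) apart, within the scatter of two such steps. Among the compounds shown here, the chloro change likewise shows no measurable difference between its two cores, but with one pair for each change, this shows only that the four values fit a transfer between these cores, not that either change would carry to any other core: the same change on two cores in this assay, a 1.8-fold higher number (0.26 log units; within the scatter) from compound 1 to compound 3 and a 1.2-fold lower number (0.07 log units; within the scatter) from compound 2 to compound 4, 2.1-fold (0.33 log units) apart, within the scatter of two such steps.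

Open, from the compounds shown here alone, is whether the iodo change would read the same on a core whose chain is longer or ends in an amine or a carboxylic acid. Also open, going by these compounds, is how bromo or methoxy on the same aromatic carbon would compare with iodo and isopropyl on either core.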